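The source may hold more compounds than are shown below. What is called first, only, known or untested is meant among the compounds shown, and "the series" means these compounds.

Among the compounds with values here, the series has two measured members so far. Compound 1 `CN1C[C@H](C(=O)Nc2ccc(Br)cc2)[C@@H](c2ccc(/C=C/C(=O)Nc3ccccc3N)cc2)C1` gives 3 mL/min/kg in an in vitro ADME assay on microsomes from liver (Homo sapiens) for pharmacokinetics, read by LC-MS, with a stated time of 10 min, tested at 1 uM (on this read-out lower numbers stand for slow clearance and higher numbers for fast clearance), and compound 2 `COc1cccc(NC(=O)[C@H]2CN(C)C[C@@H]2c2ccc(/C=C/C(=O)Nc3ccccc3N)cc2)c1` gives 14 mL/min/kg in the same assay. The one step shown, a 4.7-fold higher number from compound 1 to compound 2 (0.67 log units; beyond the scatter), came with the change of 3-methoxyphenyl in place of 4-bromophenyl on an amide-type nitrogen, so compound 2 carries the higher of the two numbers, with compound 1 at the lower one.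

Compound 3 `CN1C[C@H](C(=O)N2CCCCC2)[C@@H](c2ccc(/C=C/C(=O)Nc3ccccc3N)cc2)C1` follows compound 2 through (piperidin-1-yl in place of (3-methoxyphenyl)amino on a carbonyl carbon). Within the data shown here, no measured step matches this change: the one available step exchanged one aryl group for another on the amide-type nitrogen, whereas here the (3-methoxyphenyl)amino group is replaced by piperidin-1-yl on the carbonyl carbon. Given that the shown step was only modest, no direction can be assigned with confidence, and a step of a 1.4-fold lower number from compound 2 to compound 3 (0.15 log units; within the scatter) is expected to fall within the scatter. Compound 3 is therefore estimated at 10 mL/min/kg, with a range from 3 mL/min/kg to 30 mL/min/kg.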

Compound 3, clearance: 9 mL/min/kg
For compound 3 the middle estimate is 1.1-fold (0.05 log units) above the measured one, within the range that was stated.
By their numbers in this assay, from the lowest: compound 1; then compounds 3 and 2 (each within the scatter of the next).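

In this assay, piperidin-1-yl in place of (3-methoxyphenyl)amino on the carbonyl carbon gives a 1.6-fold lower number from compound 2 to compound 3 (0.19 log units; within the scatter), so at this place an aromatic ring and the amide hydrogen are not needed for a number of this size. Against the other anilide, the same group gives a 3.0-fold higher number from compound 1 to compound 3 (0.48 log units; beyond the scatter), which leaves compound 1 apart from both others and shows that its low number does not go with aryl amides as such, since compound 2 is one too. No measurement offered here explains either step.

The compounds shown leave open how morpholin-4-yl or dimethylamino would read on this carbonyl carbon. They also do not separate the halogen from its ring position, which a 3-bromophenyl or 4-methoxyphenyl group on the amide nitrogen would address.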